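The source may report more compounds than this note shows. Statements on the series, on what has been measured and on what is new or still open speak of the compounds shown alone.

Compound 1 `O=C1C[C@H](O)C[C@@H](/C=C/c2c(Cl)cc(Cl)cc2-c2ccccc2)O1` gives 80 nM in an assay for inhibition of 3-hydroxy-3-methylglutaryl-coenzyme A reductase (Rattus norvegicus); a lower number here means a stronger inhibitor, a higher number a weaker inhibitor.
Compound 2 `Cc1ccccc1-c1cc(Cl)cc(Cl)c1/C=C/[C@@H]1C[C@@H](O)CC(=O)O1` gives 370 nM in this assay.
Compound 3 `O=C1C[C@H](O)C[C@@H](/C=C/c2c(Cl)cc(Cl)cc2-c2ccc(Cl)c(Cl)c2)O1` gives 25 nM in this assay.

Among these three, compound 3 has the lowest number: the nearest is compound 1, with a 3.2-fold lower number from compound 1 to compound 3 (0.51 log units; beyond the scatter) running the other way, and the furthest is compound 2, with a 15-fold lower number from compound 2 to compound 3 (1.17 log units; beyond the scatter).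

Compound 4 `Cc1cc(C)cc(-c2cc(Cl)cc(Cl)c2/C=C/[C@@H]2C[C@@H](O)CC(=O)O2)c1` has not yet been measured. It differs from compound 3 in one place: 3,5-dimethylphenyl in place of 3,4-dichlorophenyl on an aromatic carbon.

Among the compounds with values here, two measured steps bear on this. Putting a 3,4-dichlorophenyl in place of phenyl gave a 3.2-fold lower number from compound 1 to compound 3 (0.51 log units; beyond the scatter), so removing those two chloro groups would be expected to give the lost ground back. Adding a methyl to the pendant ring gave a 4.6-fold higher number from compound 1 to compound 2 (0.67 log units; beyond the scatter), a step towards weaker inhibition. Both pull the same way, so compound 4 is expected to show a modest rise, about a 6.0-fold higher number from compound 3 to compound 4 (0.78 log units; beyond the scatter), in this assay. Compound 4 is therefore estimated at 150 nM, within a range from 40 nM to 600 nM.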

Compound 4, half-maximal inhibitory concentration: 13 nM
Compound 4: the middle estimate sits 12-fold (1.06 log units) above what was measured, outside the stated range (below it).
By their numbers in this assay, from the lowest: compounds 4 and 3 (each within the scatter of the next); then compound 1; then compound 2.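

In this assay, replacing the two chloro groups of the pendant ring with two methyl groups gives a 1.9-fold lower number from compound 3 to compound 4 (0.28 log units; within the scatter), so 3,5-dimethylphenyl and 3,4-dichlorophenyl cannot be told apart at this position. Methyl groups on this ring therefore do not always weaken inhibition: 3,5-dimethylphenyl gives a 6.2-fold lower number from compound 1 to compound 4 (0.79 log units; beyond the scatter) against the plain phenyl, and a 28-fold lower number from compound 2 to compound 4 (1.45 log units; beyond the scatter) against 2-methylphenyl. The two methyl-bearing rings differ in both the number and the place of their methyl groups, so the earlier loss with 2-methylphenyl cannot be extended to every methyl on this ring.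

As far as these compounds go, it remains open how a single methyl would behave as 3-methylphenyl, and whether larger groups such as tert-butyl or methoxy would also be accepted on the ring. Nothing measured here gives a reason for these differences.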